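Replacing a Hydroxy Group by a Cyano Group

This account rests on a few compounds, and the source may have more. Where it says the series, first, only, none or still open, it means among the compounds named here.

Compound 1 `O=C(N/N=C/c1ccccc1)c1cnccn1` and compound 2 `O=C(N/N=C/c1ccccc1O)c1cnccn1` share one core and differ at a single aromatic carbon. In an ADME assay on J774 cells (Mus musculus) for cytotoxicity, read by MTT assay, with a stated time of 48 h, tested at 100 ug/mL (on this read-out lower numbers stand for a stronger effect and higher numbers for a weaker effect at the one concentration tested), compound 1 gives 75%, whereas compound 2 gives 0.3%. Among the measured compounds shown here, the only measured step, a number 74.7 percentage points lower from compound 1 to compound 2 (beyond the scatter), therefore places compound 2 at the lowest of the two numbers, with compound 1 as its sole neighbour far above it.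

Compound 3 `N#Cc1ccccc1/C=N/NC(=O)c1cnccn1` is not yet measured. It differs from compound 2 by cyano in place of hydroxy on an aromatic carbon. For the measured compounds named here, no measured step involves a cyano group, so the one step available speaks only indirectly: it shows that the hydroxy group accounts for the whole gap between compound 1 and compound 2, and compound 3 gives up that hydroxy while taking on a group of another kind. The step expected in this assay, a number 54.7 percentage points higher from compound 2 to compound 3 (beyond the scatter), is thus an upward one, but with a single supporting step its size is very uncertain. Compound 3 is estimated at 55%, within a range from 10% to 90%.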

Compound 3, a percentage reported as activity, at one concentration (the size of the read-out at that concentration, not a potency): 75%
Compound 3: the middle estimate sits 20 percentage points below what was measured; the measured number falls inside the stated range.
By their numbers in this assay, from the lowest: compound 2; then compounds 1 and 3 (each within the scatter of the next).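

In this assay, putting cyano in place of hydroxy on this aromatic carbon, ortho to a large group, gives a number 74.7 percentage points higher from compound 2 to compound 3 (beyond the scatter), so the low number of compound 2 does not carry over to a group of another kind at the same place. Set against the compound with only hydrogen there, cyano gives no change at the digits printed from compound 1 to compound 3 (within the scatter), which means that among these three compounds hydroxy alone stands apart at this position, while hydrogen and cyano cannot be told apart on this read-out. The swap also takes the count of hydrogen-bond donors in this group from 1 to 0, but that is only a count, and nothing available here explains the separation of hydroxy from the other two groups.

The compounds shown leave open how other groups on this same carbon would read, such as an amine, a methoxy group or a carboxylic acid. They also leave open whether hydroxy would give a similarly low number on a different carbon of that ring, so the result so far belongs to one group at one place.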